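Indole vinyl sulfones: removing the pendant-aryl methoxy

The source may hold more compounds than are shown below. What is called first, only, known or untested is meant among the compounds shown, and "the series" means these compounds.

Measured so far in a functional assay on EKVX cells (Homo sapiens) for inhibition, read by sulforhodamine B assay, with a stated time of 48 h; on this read-out higher numbers stand for weaker inhibition of growth and lower numbers for stronger inhibition of growth:
compound 1 `O=C(/C(=C\c1c(-c2ccccc2)[nH]c2ccccc12)S(=O)(=O)c1ccccc1)c1ccccc1` gives 4600 nM
compound 2 `COc1ccc(-c2[nH]c3ccc(OC)cc3c2/C=C(\C#N)S(=O)(=O)c2ccccc2)cc1` gives 3300 nM
compound 3 `COc1ccc(-c2[nH]c3ccccc3c2/C=C(\C#N)S(=O)(=O)c2ccccc2)cc1` gives 1300 nM

Compound 2 stands second highest of the three numbers in this assay; compound 1 is its nearest neighbour, within the scatter, and compound 3 its furthest, beyond the scatter.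

The step now followed leads from compound 2 to compound 4 `COc1ccc2[nH]c(-c3ccccc3)c(/C=C(\C#N)S(=O)(=O)c3ccccc3)c2c1`, which is not yet measured. The change is hydrogen in place of methoxy on an aromatic carbon.

For the measured compounds named here, one measured step bears on it: a 2.5-fold lower number from compound 2 to compound 3 (0.40 log units; beyond the scatter), a change of the same kind, a hydrogen in place of a methoxy, but at the other methoxy-bearing ring of compound 2. In compound 4 the methoxy that leaves is the one on the pendant aryl, so that 4-methoxyphenyl becomes phenyl. Going by the values given here, no measured pair shows this particular removal, so the step from compound 2 to compound 3 is a guide by kind only. A similar loss of methoxy gave a modest lowering; the same direction is taken as the more likely outcome here, though a step within the scatter is also plausible.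

Compound 4 is expected to give 2200 nM in this assay, with a range of 900 nM to 5500 nM. This estimate means a 1.5-fold lower number from compound 2 to compound 4 (0.18 log units; within the scatter).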

Compound 4, concentration for 50% growth inhibition: 6900 nM
Compound 4: the middle estimate sits 3.1-fold (0.50 log units) below what was measured; measured number outside the range, above it.
By their numbers in this assay, from the lowest: compound 3; then compounds 2, 1 and 4 (each within the scatter of the next, the first and the last beyond it).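

Within this assay, the change from 4-methoxyphenyl to phenyl gives a 2.1-fold higher number from compound 2 to compound 4 (0.32 log units; beyond the scatter) and is the only measured pair for this position, para to a large group. The same exchange of hydrogen for methoxy on the other methoxy-bearing ring gives a 2.5-fold lower number from compound 2 to compound 3 (0.40 log units; beyond the scatter) and runs the opposite way, so in compound 2 the direction of this change depends on which methoxy leaves, and the earlier step cannot be carried over from one ring to the other. Nothing shown gives a measured reason for this difference between the two places.

Still open, as far as these compounds go, is whether the higher number belongs to the loss of the methoxy alone or would also follow from other groups at this position, such as an amine, a hydroxy group or a longer ether like ethoxy. The compounds shown also leave open what a nitrile compound carrying neither methoxy would give, and so whether the two opposite steps simply add or depend on each other.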